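Quinolinylidene thiosemicarbazides and semicarbazides: moving to 3-chlorophenyl

The source may hold more compounds than are shown below. What is called first, only, known or untested is meant among the compounds shown, and "the series" means these compounds.

Measured so far:
compound 1 `N#Cc1ccc(NC(=S)N/N=C/c2ccc3ccccc3n2)cc1` — 4660 nM
compound 2 `Cc1ccc(NC(=O)N/N=C/c2ccc3ccccc3n2)cc1` — > 100000 nM

Among the compounds with values here, compound 1 is the only member of the series with a numerical reading in a functional assay on HL-60 cells (Homo sapiens) for antiproliferative activity, read by sulforhodamine B assay, with a stated time of 72 h (a lower number here means a stronger inhibitor, a higher number a weaker inhibitor), where compound 1 gives 4660 nM. Compound 2 returns only a limit of the assay in this assay, namely > 100000 nM, which is the situation described by the limit of > 100000 nM in this assay, at which 1 of the 2 values shown sits. Between the two there is no single-point step, so the pair says no more than the two values themselves: one numerical reading and one limit.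

The next compound, compound 3 `S=C(N/N=C/c1ccc2ccccc2n1)Nc1cccc(Cl)c1`, is not yet measured in this assay. Relative to compound 1 the change is 3-chlorophenyl in place of 4-cyanophenyl on an amide-type nitrogen. Both compounds keep the thiocarbonyl, which distinguishes them from compound 2.

Within the data shown here, with no measured step on an aryl exchange of this kind to lean on, the expectation for the move from compound 1 to compound 3 is a step of modest size in this assay, near or only somewhat beyond the scatter, with no firm direction; the estimated step is a 1.1-fold higher number from compound 1 to compound 3 (0.03 log units; within the scatter). Compound 3 is accordingly expected to give about 5000 nM in this assay, within a range of 1500 nM to 16000 nM.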

Compound 3, half-maximal inhibitory concentration: 28800 nM
Compound 3: middle estimate off by 5.8-fold (0.76 log units), on the low side, outside the stated range (above it).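

In this assay, the aryl group on the amide-type nitrogen is not a silent position: with the thiocarbonyl kept, 3-chlorophenyl in place of 4-cyanophenyl gives a 6.2-fold higher number from compound 1 to compound 3 (0.79 log units; beyond the scatter). Within the data shown here, this is the first single-place step, and it shows that an exchange of aryl groups at this nitrogen can move the reading beyond the scatter, with 4-cyanophenyl the better of the two groups compared here. Nothing on hand bears on the reason for this step.

The exchange alters both the substituent and its printed ring number, so the step cannot be assigned to either change alone, and 4-chlorophenyl and 3-cyanophenyl on the same nitrogen would separate the two, while a 4-aminophenyl group would test a different kind of substituent. In this assay compound 2 gives > 100000 nM, which is a limit of the assay and not a number, so the exchange of thiocarbonyl for carbonyl on a single aryl group remains unread.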